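Swapping Isopropyl for Cyano: Expected Liver Microsome Clearance

The source may report more compounds than this note shows. Statements on the series, on what has been measured and on what is new or still open speak of the compounds shown alone.

Of the compounds shown here, two sharing one core have been measured in an ADME assay on microsomes from liver (Mus musculus, strain CD1) for metabolic stability, read by HPLC, using NADPH, with a stated time of 30 min; a higher number here means faster removal of the compound, a lower number slower removal. Compound 1, `COc1cccc(NC(=O)c2nnn(Cc3cc(C)on3)c2N)c1`, gives 2.6 mL.min-1.g-1. Compound 2, `COc1cccc(NC(=O)c2nnn(Cc3ccc(C(C)C)cc3)c2N)c1`, gives 3.2 mL.min-1.g-1, the higher of the two numbers, although a 1.2-fold higher number from compound 1 to compound 2 (0.09 log units; within the scatter), so the two stand level. The next compound, compound 3, `COc1cccc(NC(=O)c2nnn(Cc3ccc(C#N)cc3)c2N)c1`, has not yet been measured. Its change from compound 2 is cyano in place of isopropyl on an aromatic carbon. Within the data shown here, the one measured step exchanges the whole group on the saturated chain carbon bound to the aromatic nitrogen rather than a substituent on the six-membered aromatic ring of carbon only, so it bears only loosely on this change; it does show that a sizeable swap at that end left the number within the scatter. Among the measured compounds shown here, no measured step speaks directly to cyano in place of isopropyl. For compound 3 the expected step is therefore small, a 1.3-fold lower number from compound 2 to compound 3 (0.11 log units; within the scatter). Compound 3 is expected to give 2.5 mL.min-1.g-1, within a range from 1.2 mL.min-1.g-1 to 5 mL.min-1.g-1.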

Compound 3, intrinsic clearance in microsomes in the Mus musculus assay: 2.5 mL.min-1.g-1
Compound 3: the middle estimate sits on the measured number at the digits printed; low and high end bracket the measured number.
By their numbers in the Mus musculus assay, from the lowest: compounds 3, 1 and 2 (each within the scatter of the next).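

In the Mus musculus assay the swap at this aromatic carbon gives a 1.3-fold lower number from compound 2 to compound 3 (0.11 log units; within the scatter) and the exchange of the whole group gives a 1.0-fold lower number from compound 1 to compound 3 (0.02 log units; within the scatter) so all three compounds stand level, now including a pair that differs only in the substituent on this ring. In a physicochemical assay for lipophilicity, read by HPLC, measured as chromatographic lipophilicity, at pH 7.4 (on this read-out lower numbers stand for lower lipophilicity and higher numbers for higher lipophilicity), compound 2 gives 3.4 and compound 3 gives 2.3 as its number, so this small swap separates the two compounds clearly on that scale. At this position, then, a large drop in lipophilicity comes with no readable shift in microsomal removal: the measured distribution coefficient of compound 2, 3.4, and of compound 3, 2.3, a number 1.10 log units lower (beyond the scatter).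

As far as these compounds go, whether a carboxylic acid or a primary amine on the same aromatic carbon would move the number in the Mus musculus assay beyond the scatter remains open. Which part of these molecules the microsomes attack also remains open.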